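This account rests on a few compounds, and the source may have more. Where it says the series, first, only, none or still open, it means among the compounds named here.

Working notes on the series. The shared core of compound 1, `O=S(=O)(c1ccccc1)c1nc2ccccc2nc1N1CCCC1`, carries an unsubstituted phenyl on the sulfonyl; in a functional assay on PC-3 cells (Homo sapiens) for cytotoxicity, read by MTT assay, with a stated time of 72 h (a lower number here means a stronger inhibitor, a higher number a weaker inhibitor), compound 1 gives 20800 nM. Compound 2, `O=S(=O)(c1ccc(Br)cc1)c1nc2ccccc2nc1N1CCCC1`, carries a bromo on that phenyl. In this assay compound 2 reaches only a limit of the assay, > 50000 nM, and no number. On these data alone, the step is an at least 2.4-fold higher number from compound 1 to compound 2 (0.38 log units; beyond the scatter), so compound 2 stands at the weak end of the two values shown; its exact position is unknown because the limit of > 50000 nM in this assay, at which 1 of the 2 values shown sits, is where its value sits.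

Compound 3, `O=S(=O)(c1ccc(F)cc1)c1nc2ccccc2nc1N1CCCC1`, differs from compound 2 by fluoro in place of bromo on an aromatic carbon. Going by the values given here, the only step measured bears on it indirectly: bromo in place of hydrogen moved the number from compound 1 to the limit, and the change here removes the bromo again while putting a smaller halogen in its place. Compound 3 is therefore expected to land between compound 1 and the limit of compound 2, an expected step of an at least 1.4-fold lower number from compound 2 to compound 3 (0.15 log units; that floor lies within the scatter), with a fair chance that the assay again reports only a limit. The estimate for compound 3 in this assay is 35000 nM, within a range from 15000 nM to 80000 nM.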

Compound 3, half-maximal inhibitory concentration: 12400 nM
The estimate for compound 3 lay 2.8-fold (0.45 log units) above the measured number; measured number below the stated range.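

In this assay the identity of the halogen para to a large group matters: fluoro in place of bromo gives an at least 4.0-fold lower number from compound 2 to compound 3 (0.60 log units; beyond the scatter). Fluoro in place of hydrogen gives a 1.7-fold lower number from compound 1 to compound 3 (0.22 log units; within the scatter), so compound 1 and compound 3 cannot be told apart at this position, and the presence of a halogen there does not by itself bring the weaker reading. The weak end of the series therefore goes with bromo rather than with fluoro, a contrast that rests on these two halogens alone and could not be seen from the earlier pair, which held only hydrogen and bromo.

On these data alone, the full size of the bromo-to-fluoro step stays unknown because compound 2 reports only a limit of the assay, not a number: the limit of > 50000 nM in this assay, at which 1 of the 3 values shown sits. Also open is whether any group at this position, such as an amine, a methoxy group or a carboxylic acid, gives a number lower than compound 1 by more than the usual scatter, and whether chloro would read closer to fluoro or to bromo.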